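The compounds below may be only part of what the source reports. "The series", "measured", "known", "first", "only" and "open" are said of these compounds alone.

Compounds 1, 2 and 3 share one core and differ only in the group on the carbonyl carbon. Compound 1 `COc1ccc(-c2cc3ccccc3nc2/C=C/C(=O)c2ccc(F)cc2)cc1` carries a 4-fluorophenyl there, compound 2 `COc1ccc(C(=O)/C=C/c2nc3ccccc3cc2-c2ccc(OC)cc2)cc1` a 4-methoxyphenyl, and compound 3 `COc1ccc(-c2cc3ccccc3nc2/C=C/C(=O)c2ccc(OC)cc2OC)cc1` a 2,4-dimethoxyphenyl. In a functional assay on H184B5F5/M10 cells (Homo sapiens) for antiproliferative activity, read by XTT assay, with a stated time of 72 h (a higher number here means a weaker inhibitor, a lower number a stronger inhibitor), compound 1 gives only a limit, > 10000 nM. Compound 2 also gives only a limit in this assay, > 10000 nM. Going by the values given here, compound 3 is the one compound with an actual number in this assay, 6110 nM. Both an at least 1.6-fold lower number from compound 1 to compound 3 (0.21 log units; that floor lies within the scatter) and an at least 1.6-fold lower number from compound 2 to compound 3 (0.21 log units; that floor lies within the scatter) are thus floors rather than full sizes, and a step that the two limits leave unreadable from compound 1 to compound 2 cannot be read at all, since (the limit of > 10000 nM in this assay, at which 2 of the 3 values shown sit).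

Compound 4 `COc1ccc(-c2cc3ccccc3nc2/C=C/C(=O)c2ccccn2)cc1` differs from compound 3 in pyridin-2-yl in place of 2,4-dimethoxyphenyl on a carbonyl carbon. Among the compounds with values here, no measured step covers a pyridin-2-yl. What the measured steps do show is that, among these three, only the 2,4-dimethoxyphenyl of compound 3 brought the number under the limit, and compound 4 gives that group up. One therefore expects a step of a 1.5-fold higher number from compound 3 to compound 4 (0.17 log units; within the scatter), toward a weaker inhibitor. Compound 4 is estimated at 9000 nM, within 3000 nM to 30000 nM, with a real chance that this assay returns only a limit.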

Compound 4, half-maximal inhibitory concentration: 4140 nM
For compound 4 the middle estimate is 2.2-fold (0.34 log units) above the measured one, and the stated range covers the measured number.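

Going by these compounds alone, on the carbonyl carbon, the 2,4-dimethoxyphenyl proves not to be the only group that yields an actual number in this assay, since the pyridin-2-yl of compound 4 does so as well. Exchanging one for the other gives a 1.5-fold lower number from compound 3 to compound 4 (0.17 log units; within the scatter), so the two groups cannot be ranked. Against the other two groups the pyridin-2-yl shows an at least 2.4-fold lower number from compound 2 to compound 4 (0.38 log units; beyond the scatter) and an at least 2.4-fold lower number from compound 1 to compound 4 (0.38 log units; beyond the scatter), and both steps are floors, since the values they start from are limits: the limit of > 10000 nM in this assay, at which 2 of the 4 values shown sit.

From the compounds shown here alone, it remains open how an unsubstituted phenyl or a pyridin-4-yl on the carbonyl carbon would read in this assay, which would help to show whether the ring nitrogen of compound 4 matters at all. Also open, going by these compounds, is whether an amine or a carboxylic acid on that ring would change the number.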